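The source may report more compounds than this note shows. Statements on the series, on what has been measured and on what is new or still open speak of the compounds shown alone.

Compound 1 `CN(Cc1cccs1)C1CCN(CCCc2c[nH]c3ccc(-n4cnnc4)cc23)CC1` is the starting point of this account. In an assay on CHO cells for displacement of a labelled ligand from 5-hydroxytryptamine receptor 1B (Homo sapiens) (on this read-out lower numbers stand for stronger inhibition and higher numbers for weaker inhibition), compound 1 gives 140 nM, which places it second highest among the three numbers recorded. Its nearest neighbour is compound 3 `CC(=O)Nc1ccc(CN(C)C2CCN(CCCc3c[nH]c4ccc(-n5cnnc5)cc34)CC2)cc1`, which in this assay gives 100 nM; the step of a 1.4-fold lower number from compound 1 to compound 3 (0.15 log units; within the scatter) lies within the scatter. Going by the values given here, the furthest is compound 2 `OC[C@H](NC1CCN(CCCc2c[nH]c3ccc(Cn4cncn4)cc23)CC1)c1ccccc1`, which in this assay gives 1300 nM, a number well beyond the scatter from compound 1, though compound 2 differs from compound 1 in more than one place and no single step to it is recorded.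

Compound 4 `c1ccc2c(c1)CCC2NCC1CCN(CCCc2c[nH]c3ccc(-n4cnnc4)cc23)CC1` has not yet been measured. It differs from compound 1 in one place: ((2,3-dihydro-1H-inden-1-yl)amino)methyl in place of methyl((thiophen-2-yl)methyl)amino on a saturated ring carbon. Among the compounds with values here, the only single-place step recorded, from compound 1 to compound 3, changed the aryl group on the chain carbon and stayed within the scatter, but it did not touch the amine itself; for an exchange that replaces a methyl-bearing amine with a secondary amine set one carbon further from the ring, no recorded step applies directly. Compound 4 is therefore expected to stay close to compound 1, with the estimated step of a 1.6-fold higher number from compound 1 to compound 4 (0.20 log units; within the scatter) carrying a wide range, giving an estimate for compound 4 in this assay of 220 nM, between 60 nM and 800 nM.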

Compound 4, half-maximal inhibitory concentration: 25 nM
Compound 4: middle estimate off by 8.8-fold (0.94 log units), on the high side, and the stated range ends above it.
By their numbers in this assay, from the lowest: compound 4; then compounds 3 and 1 (each within the scatter of the next); then compound 2.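

In this assay, the exchange on the saturated ring carbon gives a 5.6-fold lower number from compound 1 to compound 4 (0.75 log units; beyond the scatter). The earlier recorded step, a 1.4-fold lower number from compound 1 to compound 3 (0.15 log units; within the scatter), changed only the aryl group and left the amine in place, whereas replacing methyl((thiophen-2-yl)methyl)amino with ((2,3-dihydro-1H-inden-1-yl)amino)methyl shows that a change at this position can move the number beyond the scatter. No measurement offered here accounts for the shift.

The exchange alters the amine, its attachment to the ring carbon and the ring system together, so the compounds shown do not tell which of these parts carries the difference. On these data alone, it remains open whether a benzylamino group or a methyl on the nitrogen of the ((2,3-dihydro-1H-inden-1-yl)amino)methyl group would keep the number this low.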